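A few compounds are considered here, and "the series" means these few. Any claim that something is new, unique, unknown or untested is made for them only; others in the source may bear on it.

Measured in an ADME assay on Vero cells (Chlorocebus sabaeus) for cytotoxicity, read by MTT assay, with a stated time of 96 h; on this read-out lower numbers stand for higher toxicity in this test and higher numbers for lower toxicity in this test:
Compound 1 `CC(=O)c1ccc2[nH]c(-c3ccc(Cl)cc3)nc2c1`: > 100000 nM, a limit.
Compound 2 `CC(=O)c1ccc2c(c1)nc(-c1ccc(Cl)cc1)n2C1CCCCC1`: > 100000 nM, a limit.
Compound 3 `CC(=O)c1ccc2c(c1)nc(-c1ccc(C(F)(F)F)cc1)n2C1CCCCC1`: 35000 nM.

Compound 2 sits at the limit of > 100000 nM in this assay, at which 2 of the 3 values shown sit, so its true position is not known. Compound 4 `CC(=O)c1ccc2c(c1)nc(-c1ccccn1)n2C1CCCCC1` carries pyridin-2-yl in place of 4-chlorophenyl on an aromatic carbon, which is pyridin-2-yl in place of 4-chlorophenyl on an aromatic carbon. One measured step, a step that the two limits leave unreadable from compound 1 to compound 2, concerns cyclohexyl in place of hydrogen on an aromatic nitrogen and offers no size. The other, an at least 2.8-fold lower number from compound 2 to compound 3 (0.45 log units; beyond the scatter), alters the group that compound 4 replaces, with trifluoromethyl in place of chloro. A modest move toward lower numbers in this assay is therefore expected, at most, and the estimated step is an at least 1.2-fold lower number from compound 2 to compound 4 (0.09 log units; that floor lies within the scatter). For compound 4 the estimate is 80000 nM, with an expected range from 30000 nM to 180000 nM.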

Compound 4, half-maximal cytotoxic concentration: > 90000 nM
Compound 4 gave a limit, no number; the forecaster's own chance of this, stated with the estimate: 55%; at least 1.1-fold (0.05 log units) between middle value and limit.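

In this assay, within the data shown here, compound 2 and compound 4 both gave limits rather than numbers, so no step between them can be read. On these data alone, whether pyridin-2-yl in place of 4-chlorophenyl changes the half-maximal cytotoxic concentration at all remains open.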